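Saturating the Acid Linker of a Pyridine-Naphthalene Inhibitor

A few compounds are considered here, and "the series" means these few. Any claim that something is new, unique, unknown or untested is made for them only; others in the source may bear on it.

Compound 2 `O=C(O)/C=C/c1ccncc1-c1ccc2ccccc2c1` is the free carboxylic acid of this small set. In an assay on a protein complex for inhibition of CDK8/Cyclin C (Homo sapiens), with a stated time of 1 h (a lower number here means a stronger inhibitor, a higher number a weaker inhibitor), compound 2 gives 5 nM, the lowest number among the three measured compounds. Its two amide relatives sit higher: compound 1 `CN1CCN(C(=O)/C=C/c2ccncc2-c2ccc3ccccc3c2)CC1` gives 43.6 nM in this assay, and compound 3 `O=C(/C=C/c1ccncc1-c1ccc2ccccc2c1)N1CCOCC1` gives 60.3 nM. The steps among them are an 8.7-fold lower number from compound 1 to compound 2 (0.94 log units; beyond the scatter), a 12-fold higher number from compound 2 to compound 3 (1.08 log units; beyond the scatter) and a 1.4-fold higher number from compound 1 to compound 3 (0.14 log units; within the scatter), so replacing the acid by either amide costs potency clearly, while the two amides are indistinguishable within the scatter.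

Compound 4 `O=C(O)CCc1ccncc1-c1ccc2ccccc2c1` keeps the acid but changes the linker: 2-carboxyethyl in place of 2-carboxyethenyl on an aromatic carbon. For the measured compounds named here, none of the measured steps touches this part of the molecule; all three swap groups on the carbonyl carbon and leave the double bond in place. Going by the values given here, they therefore give no direct precedent for the size of this step, and only show that the acid end of compound 2 is where the strongest number was found. Removing the double bond changes the shape of the linker while keeping the acid, which is expected to cost something, though not as much as losing the acid did. For compound 4 the estimate in this assay is 30 nM, within a range of 5 nM to 200 nM, an expected step of a 6.0-fold higher number from compound 2 to compound 4 (0.78 log units; beyond the scatter).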

Compound 4, half-maximal inhibitory concentration: 50.5 nM
For compound 4 the middle estimate is 1.7-fold (0.23 log units) below the measured one; measured number inside the range.
By their numbers in this assay, from the lowest: compound 2; then compounds 1, 4 and 3 (each within the scatter of the next).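

For the compounds shown here, every earlier step changed the group on the carbonyl carbon, so this is the first look at the linker itself: with the acid kept, 2-carboxyethyl in place of 2-carboxyethenyl gives a 10-fold higher number from compound 2 to compound 4 (1.00 log units; beyond the scatter) in this assay even though the two groups have the same heavy atoms and differ by a single double bond outside aromatic rings. The low number of compound 2 therefore depends on the double bond as well as on the acid, as the step of a 12-fold higher number from compound 2 to compound 3 (1.08 log units; beyond the scatter) showed for the acid end when morpholin-4-yl replaced hydroxy. No measurement given here explains why removing the double bond raises the number.

The compounds shown cannot tell whether a triple bond in the linker, or a longer chain carrying the acid, would give a number closer to that of compound 2 or to that of compound 4. From the compounds shown here alone, it also remains open how a morpholin-4-yl or 4-methylpiperazin-1-yl amide would behave on the 2-carboxyethyl linker, where the double bond is already gone.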